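Swapping propylsulfanyl for cyclohexylamino at the cytotoxicity limit

The source may report more compounds than this note shows. Statements on the series, on what has been measured and on what is new or still open speak of the compounds shown alone.

Values in an ADME assay on BCBL1 cells (Homo sapiens) for cytotoxicity, with a stated time of 7 days; on this read-out lower numbers stand for higher toxicity in this test and higher numbers for lower toxicity in this test:
- Compound 1 `Nc1nc(OCC(F)(F)F)c2ncn(/C=C3/CC3(CO)CO)c2n1`: > 20000 nM
- Compound 2 `CCOc1nc(N)nc2c1ncn2/C=C1/CC1(CO)CO`: > 20000 nM
- Compound 3 `CCCSc1nc(N)nc2c1ncn2/C=C1/CC1(CO)CO`: > 20000 nM

In this assay compound 3 gives > 20000 nM, which is a limit and not a number. It has no measured rank among the three compounds, and the set as a whole shows (the limit of > 20000 nM in this assay, at which 3 of the 3 values shown sit).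

The next structure, compound 4 `Nc1nc(NC2CCCCC2)c2ncn(/C=C3/CC3(CO)CO)c2n1`, carries cyclohexylamino in place of propylsulfanyl on an aromatic carbon.

Two measured steps are also swaps on an aromatic carbon: a step that the two limits leave unreadable from compound 2 to compound 3 and a step that the two limits leave unreadable from compound 1 to compound 3. A third changes the chain of the group instead: a step that the two limits leave unreadable from compound 1 to compound 2. None of the three has a readable size, so they offer no measured yardstick. Going by the values given here, no measured compound carries cyclohexylamino either. The expectation therefore rests only on all three compounds reaching the same limit, and no direction can be firmly expected. The expected step is a step that the limit leaves unreadable from compound 3 to compound 4. Most likely, the result for compound 4 will again be only a limit. If a number does appear, it is expected close to that limit. For compound 4 the estimate is 22000 nM, with an expected range from 8000 nM to 50000 nM.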

Compound 4, half-maximal cytotoxic concentration: > 20000 nM
Compound 4: a limit, no number (the forecaster's own chance of this, stated with the estimate: 70%); the middle value does not contradict the limit.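

In this assay compound 4 gives > 20000 nM, which is a limit and not a number. Its steps from compound 1, compound 2 and compound 3 therefore cannot be read, and all the compounds share one limit: the limit of > 20000 nM in this assay, at which 4 of the 4 values shown sit.

The compounds shown leave open whether any of these groups on the aromatic carbon changes the value in this assay at all, and in which direction.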